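A few compounds are considered here, and "the series" means these few. Any claim that something is new, unique, unknown or untested is made for them only; others in the source may bear on it.

In a functional assay on MCF7 cells (Homo sapiens) for antiproliferative activity, read by MTT assay, with a stated time of 48 h (a lower number here means a stronger inhibitor, a higher number a weaker inhibitor), compound 1 `CNCC(=O)Nc1cc(OC)ccc1C(=O)c1ccc(OC)c2c1OC(C)(C)C=C2` gives 820 nM and compound 2 `CCNCC(=O)Nc1cc(OC)ccc1C(=O)c1cc(OC)c(OC)c(OC)c1` gives 1050 nM so the two numbers lie within the usual scatter of each other. Neither compound can be ranked above the other on this evidence.

Compound 3 `COc1ccc(C(=O)c2cc(OC)c(OC)c(OC)c2)c(NC(=O)CN)c1` has not yet been measured. It follows from compound 2 by a single change, hydrogen in place of ethyl on an amine nitrogen, and the rest of the structure stays the same.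

Among the compounds with values here, no two measured compounds differ in only one place, so the data give no direct measure of this change. No direction is favoured, and no shift beyond the scatter is expected in this assay for this step. The expected change is a 1.1-fold lower number from compound 2 to compound 3 (0.02 log units; within the scatter) and the uncertainty around it is wide. Compound 3 is estimated at 1000 nM with an expected range from 300 nM to 3500 nM in this measurement.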

Compound 3, half-maximal inhibitory concentration: 270 nM
Estimate against measurement, compound 3: 3.7-fold (0.57 log units) above; the measured number lies below the stated range.
By their numbers in this assay, from the lowest: compound 3; then compounds 1 and 2 (each within the scatter of the next).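

In this assay the amine nitrogen proves to be a place where a single change matters: hydrogen in place of ethyl gives a 3.9-fold lower number from compound 2 to compound 3 (0.59 log units; beyond the scatter) and this step lies beyond the scatter. Within the data shown here, it is the first direct reading of one change in this set, and it shows that the ethyl group is not needed for the activity of compound 2 in this assay, with the free amino form giving the lower number. Nothing measured here accounts for this shift.

The compounds shown leave open how methyl, a longer chain such as propyl, or a second substituent as in dimethylamino would read on this nitrogen. Also open, from the compounds shown here alone, is whether ethylamino to amino gives a similar step on the core of compound 1, which carries methylamino and has no partner here that differs in only that place.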